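Monkey exposure after a swap on the fused-ring core

A few compounds are considered here, and "the series" means these few. Any claim that something is new, unique, unknown or untested is made for them only; others in the source may bear on it.

Measured so far:
- compound 1, `CCCCN(c1nc2ccccc2o1)[C@H](C)c1ccc(-c2ccccc2-c2nnn[nH]2)cc1`: 44.3 ng.h/mL
- compound 2, `CCCCN(c1nc2c(C(=O)NC)cccc2o1)[C@H](C)c1ccc(-c2ccccc2-c2nnn[nH]2)cc1`: 25.7 ng.h/mL

In an ADME assay on the whole organism (Macaca fascicularis) for pharmacokinetics, read by LC-MS, using cassette dosing, at a dose of 1 mg/kg by the oral route (a higher number here means more compound in the circulation at the dose given, a lower number less compound in the circulation), compound 2 gives 25.7 ng.h/mL, the lowest of the two numbers; its nearest neighbour, compound 1, gives 44.3 ng.h/mL, and a 1.7-fold lower number from compound 1 to compound 2 (0.24 log units; within the scatter). Compound 3, `CCCCN(c1nc2c(-c3nccn3C)cccc2o1)[C@H](C)c1ccc(-c2ccccc2-c2nnn[nH]2)cc1`, differs from compound 2 by 1-methyl-1H-imidazol-2-yl in place of methylcarbamoyl on an aromatic carbon. For the measured compounds named here, the only measured step, putting methylcarbamoyl in place of hydrogen at this position, stayed within the scatter, and no step exchanges two groups here, so the expectation for compound 3 is a step no larger than the scatter, in either direction. Compound 3 is estimated at 30 ng.h/mL, between 12 ng.h/mL and 75 ng.h/mL, meaning a 1.2-fold higher number from compound 2 to compound 3 (0.07 log units; within the scatter).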

Compound 3, area under the concentration-time curve: 152 ng.h/mL
Compound 3: the middle estimate sits 5.1-fold (0.70 log units) below what was measured, outside the stated range (above it).
By their numbers in this assay, from the lowest: compounds 2 and 1 (each within the scatter of the next); then compound 3.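

In this assay, this position proves able to shift the number beyond the scatter: 1-methyl-1H-imidazol-2-yl in place of methylcarbamoyl gives one step (a 5.9-fold higher number from compound 2 to compound 3 (0.77 log units; beyond the scatter)), and in place of hydrogen gives another (a 3.4-fold higher number from compound 1 to compound 3 (0.54 log units; beyond the scatter)). Methylcarbamoyl alone had shown no such step. Nothing measured here explains the gain. As far as these compounds go, whether the gain needs this particular five-membered aromatic ring stays open, as does how an amine or a carboxylic acid on the same aromatic carbon would compare.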